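Working notes: piperidin-1-yl in place of pyrrolidin-1-yl

The source may hold more compounds than are shown below. What is called first, only, known or untested is meant among the compounds shown, and "the series" means these compounds.

- compound 1 (`CCCCc1nc(C)c(CCC(=O)N2CCSCC2)c(=O)n1Cc1ccc(-c2ccccc2-c2nnn[nH]2)cc1`) gives 0.204 mg/kg
- compound 2 (`CCCCc1nc(C)c(CCC(=O)N2CCCC2)c(=O)n1Cc1ccc(-c2ccccc2-c2nnn[nH]2)cc1`) gives 0.206 mg/kg

In an in vivo functional assay on the whole organism for inhibition, with Rattus norvegicus as the target (on this read-out lower numbers stand for an effect already at smaller amounts and higher numbers for an effect only at larger amounts of compound), compound 2 stands at 0.206 mg/kg and so lies within the scatter of compound 1 at 0.204 mg/kg with neither ahead of the other. Compound 3 (`CCCCc1nc(C)c(CCC(=O)N2CCCCC2)c(=O)n1Cc1ccc(-c2ccccc2-c2nnn[nH]2)cc1`) is the next case. Its change from compound 2 is piperidin-1-yl in place of pyrrolidin-1-yl on a carbonyl carbon on a carbonyl carbon whose other neighbours are a saturated chain carbon.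

Among the measured compounds shown here, only one measured step bears on this change, namely pyrrolidin-1-yl in place of thiomorpholin-4-yl on the same carbonyl carbon. That step is a 1.0-fold higher number from compound 1 to compound 2 (0.00 log units; within the scatter) and it stays within the scatter. For the measured compounds named here, it is a single step, so it gives no general rule, and no compound with piperidin-1-yl has a measured value yet. Going by that one step, no change beyond the scatter is expected in this assay in either direction. The expected step is a 1.0-fold higher number from compound 2 to compound 3 (0.01 log units; within the scatter) and no direction is implied by it. Compound 3 is estimated at 0.21 mg/kg with an expected range from 0.09 mg/kg to 0.5 mg/kg for its measurement.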

Compound 3, dose for half-maximal effect: 0.164 mg/kg
Estimate against measurement, compound 3: 1.3-fold (0.11 log units) above, within the range that was stated.
By their numbers in this assay, from the lowest: compounds 3, 1 and 2 (each within the scatter of the next).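

With a third ring on the carbonyl carbon, the position can now be read across a change in ring size as well as a change of ring atom: in this assay, piperidin-1-yl in place of pyrrolidin-1-yl gives a 1.3-fold lower number from compound 2 to compound 3 (0.10 log units; within the scatter), and piperidin-1-yl in place of thiomorpholin-4-yl gives a 1.2-fold lower number from compound 1 to compound 3 (0.09 log units; within the scatter), so neither step leaves the scatter. Together with the earlier step, all three pairs of saturated rings now compare within the scatter, and none of compounds 1, 2 and 3 goes against this flat picture, which holds for these three compounds only. No measurement here offers an explanation for this flat picture.

As far as these compounds go, it remains open whether a morpholin-4-yl or 4-methylpiperazin-1-yl ring, or an open-chain diethylamino group, on the same carbonyl carbon would stay within the same narrow spread. Also open, from the compounds shown here alone, is how a free carboxylic acid in place of the amide, or a chain longer than the 2-((piperidin-1-yl)carbonyl)ethyl chain, would read out.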